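Trimming a Sulfated Side Chain Down to a Diol

The source may hold more compounds than are shown below. What is called first, only, known or untested is meant among the compounds shown, and "the series" means these compounds.

Of the compounds shown here, two have been measured so far in a functional assay on A-375 cells (Homo sapiens), read by thymidine incorporation; a lower number here means a stronger inhibitor, a higher number a weaker inhibitor. Compound 1, `CCCCCCCC/C=C\CCCCCCCC(=O)N[C@H]1[C@@H](OCCCCCCCC)O[C@H](CO)[C@@H](O)[C@@H]1O`, gives 6 uM. Compound 2, `CCCCC(=O)N[C@H]1[C@@H](OCCc2ccccc2)O[C@H](COCC(CO)(CO)COS(=O)(=O)O)[C@@H](O)[C@@H]1O`, gives 9.3 uM. Going by the values given here, of the two numbers, the one for compound 2 is the higher, but the gap between compound 2 and compound 1 lies within the usual scatter of repeated measurements, so the two cannot be told apart on these data, and neither can be called the stronger or weaker inhibitor.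

Compound 3, `CCCCC(=O)N[C@H]1[C@@H](OCCc2ccccc2)O[C@H](COCC(O)CO)[C@@H](O)[C@@H]1O`, is the next compound to be measured. Compared with compound 2, the change is 1,2-dihydroxyethyl in place of 2-hydroxy-1-(hydroxymethyl)-1-((sulfooxy)methyl)ethyl on a saturated chain carbon bound to an oxygen on a saturated carbon. In plain terms, the branched, sulfated side chain is cut back to a short chain carrying two hydroxyl groups, while everything else in the molecule stays the same.

Among the compounds with values here, no pair of measured compounds differs in this way, so there is no measured step to lean on. The expectation is a step from compound 2 to compound 3 of a 1.2-fold lower number from compound 2 to compound 3 (0.07 log units; within the scatter), not beyond the scatter. In this assay compound 3 is therefore expected to give about 8 uM, with a range from 3 uM to 25 uM.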

Compound 3, concentration for 50% inhibition: > 50 uM
Compound 3: only a limit was reported; the forecaster's own chance of this, stated with the estimate: 10%; at least 6.2-fold (0.79 log units) between middle value and limit.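

Compound 1 and compound 2 differ in more than one place and so said nothing about any single position, whereas this first change at one place shows that the outer part of this side chain matters in this assay: putting 1,2-dihydroxyethyl in place of 2-hydroxy-1-(hydroxymethyl)-1-((sulfooxy)methyl)ethyl gives an at least 5.3-fold higher number from compound 2 to compound 3 (0.73 log units; beyond the scatter). Compound 3 gives > 50 uM in this assay, and this is a limit of the assay, not a number. From the compounds shown here alone, the step is therefore only a minimum, and how much weaker compound 3 really is stays unknown: the limit of > 50 uM in this assay, at which 1 of the 3 values shown sits.

The change removes several features at once, and these compounds cannot separate the sulfooxy group from the extra hydroxymethyl arms or from the length of the chain as the part that carries the difference. Going by these compounds, it also remains open whether a carboxylic acid, a phosphate or an amine at the end of the same side chain would hold the activity seen for compound 2, or whether a sulfooxy group on the shorter 2,3-dihydroxypropyl chain would be enough.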